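This account rests on a few compounds, and the source may have more. Where it says the series, first, only, none or still open, it means among the compounds named here.

Measured so far:
Compound 1 `COc1cc(/C=C/C(=O)/C=C/c2nc3cc(C)ccc3n2C)ccc1O` gives 4700 nM
Compound 2 `COc1ccc2c(c1)nc(/C=C/C(=O)/C=C/c1ccc(O)c(OC)c1)n2C` gives 4800 nM
Compound 3 `COc1cc(/C=C/C(=O)/C=C/c2nc3cc(Cl)ccc3n2C)ccc1O` gives 4700 nM

In a functional assay on SH-SY5Y cells (Homo sapiens) for cytotoxicity, read by MTT assay, with a stated time of 48 h (a higher number here means a weaker inhibitor, a lower number a stronger inhibitor), compound 3 gives 4700 nM and stands level with compound 1 at the digits shown, while compound 2 lies within the scatter of both. None of the three can therefore be ranked above another.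

The next compound, compound 4 `COc1cc(/C=C/C(=O)/C=C/c2nc3cc([N+](=O)[O-])ccc3n2C)ccc1O`, has nitro in place of chloro on an aromatic carbon, and nitro in place of chloro on an aromatic carbon sets out that difference in full.

Three measured steps swap groups on that same carbon. They are a 1.0-fold higher number from compound 1 to compound 2 (0.01 log units; within the scatter) and no change at the digits printed from compound 1 to compound 3 (within the scatter) and a 1.0-fold lower number from compound 2 to compound 3 (0.01 log units; within the scatter) and each of them stays within the scatter. Methyl, methoxy and chloro thus give numbers that cannot be told apart, but no nitro compound has been measured yet. In this assay no step beyond the scatter is therefore expected.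

The expected step is a 1.0-fold lower number from compound 3 to compound 4 (0.02 log units; within the scatter) and it rests on those three small steps alone.

For compound 4 the estimate is 4500 nM with an expected range from 2200 nM to 9000 nM in this read-out.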

Compound 4, half-maximal inhibitory concentration: 4600 nM
Compound 4: the middle estimate sits 1.0-fold (0.01 log units) below what was measured; the range from low to high includes it.
By their numbers in this assay, from the lowest: compounds 4, 1, 3 and 2 (each within the scatter of the next).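

In this assay, the exchange of chloro for nitro adds heavy atoms and two hydrogen-bond acceptors on this aromatic carbon, yet the result is a 1.0-fold lower number from compound 3 to compound 4 (0.01 log units; within the scatter) and the comparisons with the other two groups agree, with a 1.0-fold lower number from compound 2 to compound 4 (0.02 log units; within the scatter) and a 1.0-fold lower number from compound 1 to compound 4 (0.01 log units; within the scatter) as well. Methyl, methoxy, chloro and nitro on this carbon therefore give numbers that cannot be told apart, and the set of groups without a detectable difference now includes one with more heavy atoms than chloro. No measurement is available that explains this flat result.

On these data alone, whether an amine, a carboxylic acid or a longer chain on this same carbon would give a step beyond the scatter remains open. So does the effect of changes elsewhere on the shared core, such as replacing the methoxy group on the other aromatic ring with a hydrogen atom.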